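A few compounds are considered here, and "the series" means these few. Any claim that something is new, unique, unknown or untested is made for them only; others in the source may bear on it.

In an ADME assay on HepG2 cells (Homo sapiens) for cytotoxicity, in the presence of a further agent that is not named here (on this read-out higher numbers stand for weaker inhibition and lower numbers for stronger inhibition), compound 1 `Cn1c(Cc2ccccc2C(F)(F)F)nc(C(=O)NCc2cccnc2)c(O)c1=O` gives > 100000 nM, which is a limit of the assay rather than a number. Compound 2 `COc1nc(C(C)c2ccccc2C(F)(F)F)nc(C(=O)NCc2ccccc2)c1O` gives > 100000 nM in this assay, again a limit. Compound 1 thus stands where both values sit, at the limit of > 100000 nM in this assay, at which 2 of the 2 values shown sit, so no order among the measured compounds can be read. Compound 3 `Cn1c(Cc2ccccc2C(F)(F)F)nc(C(=O)CCc2ccccc2)c(O)c1=O` is not yet measured; it differs from compound 1 by phenethyl in place of ((pyridin-3-yl)methyl)amino on a carbonyl carbon. Going by the values given here, no measured step covers this change, and with both values at the limit no direction is expected: the step of a number no higher from compound 1 to compound 3 (the limit leaves the size open) is expected to stay within the scatter. Compound 3 is estimated at 100000 nM, between 40000 nM and 300000 nM.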

Compound 3, half-maximal inhibitory concentration: > 100000 nM
Compound 3 was reported as a limit (the forecaster's own chance of this, stated with the estimate: 80%); the middle value sits exactly at the limit.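

Compound 1 and compound 3 both sit at a limit, so no step between them can be read: the limit of > 100000 nM in this assay, at which 3 of the 3 values shown sit.

The compounds shown leave open whether phenethyl in place of ((pyridin-3-yl)methyl)amino on a carbonyl carbon shifts the read-out at all, and any order among compound 1, compound 2 and compound 3.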